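Fluoro for methylsulfanyl on the aromatic ring of compound 3

A few compounds are considered here, and "the series" means these few. Any claim that something is new, unique, unknown or untested is made for them only; others in the source may bear on it.

Measured in a functional assay for inhibition, with Homo sapiens as the target; a higher number here means weaker binding, a lower number tighter binding:
- compound 1 `O=C(O)CC/C=C\CC1COC(c2ccccc2Cl)OC1c1cccnc1` gives 759 nM
- compound 2 `O=C(O)CC/C=C\CC1COC(c2cccs2)OC1c1cccnc1` gives 1000 nM
- compound 3 `CSc1ccc(OC(C)(C)C2OCC(C/C=C\CCC(=O)O)C(c3cccnc3)O2)c([N+](=O)[O-])c1` gives 4.47 nM

Compound 3 has the lowest number of the three; its nearest neighbour is compound 1, and the gap to it, as to compound 2, is beyond the scatter. Among the compounds with values here, the single measured step, a 1.3-fold higher number from compound 1 to compound 2 (0.12 log units; within the scatter), concerns a substituent on a saturated ring carbon of the shared core and says nothing about the large side group that sets compound 3 apart from the other two.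

Compound 4 `CC(C)(Oc1ccc(F)cc1[N+](=O)[O-])C1OCC(C/C=C\CCC(=O)O)C(c2cccnc2)O1` is not yet measured. It differs from compound 3 by fluoro in place of methylsulfanyl on an aromatic carbon. Within the data shown here, no measured pair alters a group on that six-membered aromatic ring, so the step to compound 4 has no direct precedent; the only step available, at a different place, lay within the scatter. The whole side group that distinguishes compound 3 from compounds 1 and 2 remains intact. The expected step is therefore small, a 1.8-fold higher number from compound 3 to compound 4 (0.25 log units; within the scatter), most likely within the scatter and of uncertain direction. For compound 4 in this assay the estimate is 8 nM, with a range from 2.5 nM to 30 nM.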

Compound 4, dissociation constant: 2.51 nM
Estimate against measurement, compound 4: 3.2-fold (0.50 log units) above, within the range that was stated.
By their numbers in this assay, from the lowest: compounds 4 and 3 (each within the scatter of the next); then compounds 1 and 2 (each within the scatter of the next).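

In this assay, within the data shown here, the step at this position, a 1.8-fold lower number from compound 3 to compound 4 (0.25 log units; within the scatter), is the first measured change on the six-membered aromatic ring of the large side group, and methylsulfanyl and fluoro cannot be told apart at this site. The position para to a large group and meta to a nitro group therefore accepts a swap from two heavy atoms, one of them sulfur and with one hydrogen-bond acceptor counted, to a single fluorine with none, and the number stays within the scatter. Among these compounds, this says only that these two groups are interchangeable here, and no measurement in hand bears on the reason for that.

From the compounds shown here alone, two substituents define no trend at this position, so it remains open whether a methoxy group, a dimethylamino group or a plain hydrogen there would also stay within the scatter of these two compounds, or whether a larger group such as phenyl would move the number beyond it. Going by these compounds, the role of the nitro group is equally open, as both compounds carry it, and an amine or a nitrile in its place would be a separate change in one place.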